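The compounds below may be only part of what the source reports. "The series", "measured", "known", "first", "only" and "open" are said of these compounds alone.

In a functional assay on NCI-H522 cells (Homo sapiens) for cytotoxicity, with a stated time of 3 days (a higher number here means a weaker inhibitor, a lower number a stronger inhibitor), compound 1 `Cn1c(I)nc2ccccc21` gives 1020 nM. Compound 2 `Cn1cnc2ccccc21` gives > 40000 nM, which is a limit of the assay and not a number. Among the compounds with values here, the only measured step is hydrogen in place of iodo, an at least 39-fold higher number from compound 1 to compound 2 (1.59 log units; beyond the scatter), and it is large and beyond the scatter. The next change leads to compound 3 `Cn1c(Br)nc2ccccc21`: bromo in place of hydrogen on an aromatic carbon. This puts bromo in place of hydrogen on the aromatic carbon between two ring nitrogen atoms, the carbon that bears iodo in compound 1. Read in reverse, the step of an at least 39-fold higher number from compound 1 to compound 2 (1.59 log units; beyond the scatter) is the one precedent, so a large move to a lower number is expected in this assay, though iodo is the only halogen measured so far. The estimated move is an at least 20-fold lower number from compound 2 to compound 3 (1.30 log units; beyond the scatter). For compound 3 the expected value is 2000 nM, with an estimated range of 500 nM to 10000 nM.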

Compound 3, half-maximal inhibitory concentration: > 40000 nM
Compound 3: a limit, no number; the forecaster's own chance of this, stated with the estimate: 10%; at least 20-fold (1.30 log units) between middle value and limit.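

At the aromatic carbon between two ring nitrogen atoms, the halogen cannot be exchanged freely in this assay: bromo in place of iodo gives an at least 39-fold higher number from compound 1 to compound 3 (1.59 log units; beyond the scatter). Among the compounds shown, only iodo at this position gives a number, so a halogen there is not enough by itself. The step between the hydrogen and bromo compounds cannot be read, because both values are limits of the assay and not numbers: the limit of > 40000 nM in this assay, at which 2 of the 3 values shown sit.

Going by these compounds, how far compound 3 lies beyond its limit remains unknown, so any gain from bromo over hydrogen stays open. Also open, on these data alone, are whether chloro, an amine or a nitrile at this carbon gives a number, and whether compound 1 keeps its value with a longer chain in place of the methyl group.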